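Five-membered ring returns at the amide, now carrying a methyl

This account rests on a few compounds, and the source may have more. Where it says the series, first, only, none or still open, it means among the compounds named here.

Measured in an assay on isolated protein for inhibition of solute carrier family 22 member 12 (Homo sapiens), tested at 3 uM; on this read-out lower numbers stand for less inhibition and higher numbers for more inhibition at the one concentration tested (going by the name of the read-out):
compound 1, `N#Cc1cc(C(=O)N2CC=CC2)cc(C(F)(F)F)c1O`, gives 83%
compound 2, `N#Cc1cc(C(=O)N2CCCC2)cc(C(F)(F)F)c1O`, gives 66%
compound 3, `N#Cc1cc(C(=O)N2CCC2)cc(C(F)(F)F)c1O`, gives 75%

Compound 3 stands second highest of these three numbers. Its nearest neighbour is compound 1, its furthest compound 2, yet both gaps lie within the scatter, as the steps of a number 8 percentage points lower from compound 1 to compound 3 (within the scatter) and a number 9 percentage points higher from compound 2 to compound 3 (within the scatter) show, so no order among them can be read.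

Compound 4, `CC1=CCN(C(=O)c2cc(C#N)c(O)c(C(F)(F)F)c2)C1`, differs from compound 3 as follows: a group of 6 heavy atoms (5 carbon, 1 nitrogen; one five-membered non-aromatic ring with 1 hetero atom) in place of a group of 4 heavy atoms (3 carbon, 1 nitrogen; one four-membered non-aromatic ring with 1 hetero atom), on a carbonyl carbon.

Both measured steps into compound 3 bear on this change, and both stayed within the scatter. Compound 1 carries a five-membered unsaturated ring of the same kind with 83%. A step within the scatter is therefore expected, a number 5 percentage points higher from compound 3 to compound 4 (within the scatter). For compound 4 the estimate is 80%, with a range from 66% to 92%.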

Compound 4, a percentage reported as inhibition, at one concentration (the size of the read-out at that concentration, not a potency): 88%
Compound 4: middle estimate off by 8 percentage points, on the low side; measured number inside the range.
By their numbers in this assay, from the lowest: compounds 2, 3, 1 and 4 (each within the scatter of the next, the first and the last beyond it).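

On the double-bonded ring carbon, methyl in place of hydrogen gives a number 5 percentage points higher from compound 1 to compound 4 (within the scatter), so the extra group brings no readable change at this carbon. Replacing azetidin-1-yl gives a number 13 percentage points higher from compound 3 to compound 4 (beyond the scatter), the first step from that ring to pass the scatter, and replacing pyrrolidin-1-yl gives a number 22 percentage points higher from compound 2 to compound 4 (beyond the scatter). Nothing measured here explains these differences. On these data alone, whether ethyl or an aminomethyl group on the same ring carbon would keep the number stays open, as does the effect of methyl on the saturated five-membered ring.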